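The source may report more compounds than this note shows. Statements on the series, on what has been measured and on what is new or still open speak of the compounds shown alone.

Measured compounds in the series:

compound 1 `CCCN(C)c1cc(C)nc2c(-c3ccc(Cl)cc3Cl)nn(C)c12` — 24 nM
compound 2 `CCCCN(CCCC)c1cc(C)nc2c(-c3ccc(Cl)cc3Cl)nn(C)c12` — 0.62 nM
compound 3 `CCCCN(c1cc(C)nc2c(-c3ccc(Cl)cc3Cl)nn(C)c12)C(CC)CC` — 7 nM

In an assay on HEK293 cells for displacement of a labelled ligand from corticotropin-releasing factor receptor 1 (Homo sapiens) (a higher number here means a weaker inhibitor, a lower number a stronger inhibitor), compound 2 stands at the lowest number of the three. The step to compound 3 is an 11-fold higher number from compound 2 to compound 3 (1.05 log units; beyond the scatter), and the step from compound 1 is a 39-fold lower number from compound 1 to compound 2 (1.59 log units; beyond the scatter); both gaps lie beyond the scatter, so compound 2 is the strongest inhibitor among the measured set. Both of these steps change the amino substituent on the shared core, and the 2,4-dichlorophenyl ring is the same in all three.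

Compound 4 `CCCCN(CCCC)c1cc(C)nc2c(-c3ccc(OC)cc3Cl)nn(C)c12` keeps the dibutylamino group of compound 2 and differs from it only on that ring: methoxy in place of chloro on an aromatic carbon. Among the measured compounds shown here, no measured pair in this set alters the aryl ring, so neither a 39-fold lower number from compound 1 to compound 2 (1.59 log units; beyond the scatter) nor an 11-fold higher number from compound 2 to compound 3 (1.05 log units; beyond the scatter) bears directly on this change; they only show that the series is sensitive to substituent changes of this general scale. For the measured compounds named here, with no direct precedent, the working expectation is a modest shift, not clearly beyond the scatter. For compound 4 the estimate in this assay is 1.5 nM, with a range of 0.4 nM to 6 nM, which would mean an expected step of a 2.4-fold higher number from compound 2 to compound 4 (0.38 log units; beyond the scatter).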

Compound 4, inhibition constant: 4.8 nM
Estimate against measurement, compound 4: 3.2-fold (0.51 log units) below; the range from low to high includes it.
By their numbers in this assay, from the lowest: compound 2; then compounds 4 and 3 (each within the scatter of the next); then compound 1.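

In this assay the aryl ring proves to be a sensitive position as well: with dibutylamino held constant, methoxy in place of chloro, para to a large group and meta to a chloro group, gives a 7.7-fold higher number from compound 2 to compound 4 (0.89 log units; beyond the scatter) and so a weaker inhibitor. Among the compounds shown here, the earlier steps, a 39-fold lower number from compound 1 to compound 2 (1.59 log units; beyond the scatter) and an 11-fold higher number from compound 2 to compound 3 (1.05 log units; beyond the scatter), changed only the amino substituent, so this is the first reading on the ring, and it shows that the 2,4-dichlorophenyl to 2-chloro-4-methoxyphenyl change is not neutral. No measurement at hand accounts for the size of this step.

Open, on these data alone, is whether the step belongs to methoxy itself or to any replacement of that chloro; a fluoro, methyl or trifluoromethyl group in the same place on the dibutylamino compound would separate the two. Also open, as far as these compounds go, are the contribution of the chloro group that stays in compound 4 and whether the amino substituent steps carry over to the 2-chloro-4-methoxyphenyl ring.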